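Swapping the Sulfonyl Aryl Group in a Fluorinated Core

The source may report more compounds than this note shows. Statements on the series, on what has been measured and on what is new or still open speak of the compounds shown alone.

Going by the values given here, compound 1 `COc1ccc(-c2c(S(=O)(=O)c3cc(F)cc(F)c3)cnc3c(F)cccc23)cc1` was tested in an ADME assay on microsomes from liver (Homo sapiens) for metabolic stability, tested at 2.5 uM (a higher number here means faster removal of the compound, a lower number slower removal), and gives 2.59 mL/min, which is the lowest of the two numbers so far. Its nearest neighbour is compound 2 `COc1cccc(-c2c(S(=O)(=O)c3cc(F)cc(F)c3)cnc3c(F)cccc23)c1`, which in this assay gives 2.76 mL/min; the step of a 1.1-fold higher number from compound 1 to compound 2 (0.03 log units; within the scatter) is within the scatter, so these two compounds cannot be told apart on this measure.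

Compound 3 `COc1ccc(-c2c(S(=O)(=O)c3ccc(OC)cc3)cnc3c(F)cccc23)cc1` has not yet been measured. It differs from compound 1 in one place: 4-methoxyphenyl in place of 3,5-difluorophenyl on a sulfonyl sulfur. Among the compounds with values here, the only measured step, from compound 1 to compound 2, changes a different part of the molecule and so says nothing about this swap on the sulfonyl sulfur. Within the data shown here, with no comparable step to lean on, the expectation for compound 3 is a number close to that of compound 1, with any move likely staying within the scatter: a 1.2-fold higher number from compound 1 to compound 3 (0.06 log units; within the scatter) is the estimated step. Compound 3 is thus expected to give about 3 mL/min, with a range from 1.5 mL/min to 6 mL/min.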

Compound 3, intrinsic clearance in a liver preparation (reported as CLH), per the amount of preparation that the assay uses: 2.12 mL/min
The estimate for compound 3 lay 1.4-fold (0.15 log units) above the measured number, within the range that was stated.
By their numbers in this assay, from the lowest: compounds 3, 1 and 2 (each within the scatter of the next).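

Going by these compounds alone, until now only the methoxyphenyl on the aromatic carbon had been varied, so this is the first view of the group on the sulfonyl sulfur. In this assay, the swap gives a 1.2-fold lower number from compound 1 to compound 3 (0.09 log units; within the scatter), so compound 1 and compound 3 cannot be told apart on this measure. On this one measure, 4-methoxyphenyl and 3,5-difluorophenyl can stand in for each other on the sulfonyl sulfur, even though the two fluorines leave and a methoxy group with one hydrogen-bond acceptor enters, and nothing available explains this result.

Both groups are six-membered carbon aromatic rings with the same count of heavy atoms, so this says little about very different groups. Open questions include how a ring carrying an amine or a carboxylic acid would behave on the sulfonyl sulfur, or a longer chain in place of the ring.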